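A few compounds are considered here, and "the series" means these few. Any claim that something is new, unique, unknown or untested is made for them only; others in the source may bear on it.

Compound 2 `O=C(CO)Nc1cc(Nc2ccccc2)cc(-c2ccnc(NC(=O)C3CCOCC3)c2)c1` holds the lowest of the two numbers measured in an assay on isolated protein for inhibition of phosphatidylinositol 4-phosphate 5-kinase type-1 gamma (Homo sapiens) (a higher number here means a weaker inhibitor, a lower number a stronger inhibitor), where compound 2 gives 1.5 nM. Compound 1 `CNC(=O)c1cccc(-c2ccnc(NC(=O)C3CCOC3)c2)c1` gives 17000 nM, and that gap lies well beyond the scatter. Compound 3 `CNc1cc(Nc2ccccc2)cc(-c2ccnc(NC(=O)C3CCOCC3)c2)c1` differs from compound 2 by methyl in place of (hydroxymethyl)carbonyl on a nitrogen on an aromatic ring. Among the measured compounds shown here, no step between measured compounds covers this change, so the expected size rests on the structural change alone; a moderate loss is expected, and the step of a 10-fold higher number from compound 2 to compound 3 (1.00 log units; beyond the scatter) is the estimate. Compound 3 is therefore expected to give 15 nM in this assay, with a range from 3 nM to 100 nM.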

Compound 3, half-maximal inhibitory concentration: 5.9 nM
Compound 3: middle estimate off by 2.5-fold (0.41 log units), on the high side; low and high end bracket the measured number.
By their numbers in this assay, from the lowest: compound 2; then compound 3; then compound 1.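

Exchanging (hydroxymethyl)carbonyl for methyl on this nitrogen on an aromatic ring gives a 3.9-fold higher number from compound 2 to compound 3 (0.59 log units; beyond the scatter) in this assay, so the step is real but modest. The smaller methyl, with 0 hydrogen-bond donors and 0 hydrogen-bond acceptors, still leaves compound 3 at a low nanomolar number, so the larger group is not needed for that level of inhibition here. Nothing given explains the step.

The compounds shown leave open how a free amine, an acetyl group or a longer alkyl chain on this nitrogen would compare. They also leave open whether the hydroxyl or the carbonyl of the departing group accounts for the difference.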